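Furan-2-yl to thiophen-2-yl on the shared core

The source may report more compounds than this note shows. Statements on the series, on what has been measured and on what is new or still open speak of the compounds shown alone.

Compound 1 `COc1cc(-c2cccc3nc(-c4cccc(Cl)c4)oc23)cc(OC)c1OC`: > 25000 nM, a limit of the assay
Compound 2 `COc1cc(-c2nc3cccc(-c4cc(OC)c(OC)c(OC)c4)c3o2)ccc1O`: 15700 nM
Compound 3 `COc1cc(-c2cccc3nc(-c4ccco4)oc23)cc(OC)c1OC`: 10300 nM

All three compounds were tested in a functional assay on A549 cells (Homo sapiens) for antiproliferative activity, read by MTT assay, with a stated time of 48 h; on this read-out lower numbers stand for stronger inhibition and higher numbers for weaker inhibition. For the measured compounds named here, compound 3 stands within the scatter of compound 2, with a 1.5-fold lower number from compound 2 to compound 3 (0.18 log units; within the scatter), and no other measured compound gives a number for comparison. The next compound, compound 4 `COc1cc(-c2cccc3nc(-c4cccs4)oc23)cc(OC)c1OC`, has not yet been measured. It carries thiophen-2-yl in place of furan-2-yl on an aromatic carbon of the five-membered aromatic ring with 1 nitrogen and 1 oxygen: thiophen-2-yl in place of furan-2-yl on an aromatic carbon.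

Going by the values given here, no measured step makes this exact exchange. Two steps reach compound 3 by changing the same place, with larger exchanges: an at least 2.4-fold lower number from compound 1 to compound 3 (0.38 log units; beyond the scatter), and the step from compound 2 noted above. Neither is large, and the entering group matches the leaving one in every count. No step beyond the scatter is therefore expected in this assay, and the expected change is a 1.1-fold higher number from compound 3 to compound 4 (0.03 log units; within the scatter). For compound 4 the estimated value is 11000 nM, with an expected range from 5000 nM to 25000 nM.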

Compound 4, half-maximal inhibitory concentration: 12500 nM
Compound 4: the middle estimate sits 1.1-fold (0.06 log units) below what was measured, and the stated range covers the measured number.
By their numbers in this assay, from the lowest: compounds 3, 4 and 2 (each within the scatter of the next). At a limit, above all of these: compound 1.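

In this assay, thiophen-2-yl in place of furan-2-yl, on an aromatic carbon next to the ring nitrogen and next to the ring oxygen, gives a 1.2-fold higher number from compound 3 to compound 4 (0.08 log units; within the scatter), so this exchange of one five-membered aromatic ring for another leaves the read-out within the scatter. The two-ring comparison also extends to 4-hydroxy-3-methoxyphenyl, with a 1.3-fold lower number from compound 2 to compound 4 (0.10 log units; within the scatter). Against the 3-chlorophenyl of compound 1, whose value is a limit of the assay, the step is an at least 2.0-fold lower number from compound 1 to compound 4 (0.30 log units; that floor lies within the scatter), so the separation from compound 1 seen with compound 3 is not established for compound 4.

From the compounds shown here alone, whether any group at this position can lower the number beyond the scatter of compound 2, compound 3 and compound 4 stays open. So does whether an amine or a carboxylic acid on that carbon would behave as these aromatic rings do.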